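Trading a Terminal Methyl for Iodine on a Long Chain

This account rests on a few compounds, and the source may have more. Where it says the series, first, only, none or still open, it means among the compounds named here.

Compound 1 `CCCCCCCCCCc1cc2cn([C@H]3C[C@H](O)[C@@H](CO)O3)c(=O)nc2o1` carries a long saturated chain on its core. In a functional assay for cytotoxicity, read by microscopy (on this read-out lower numbers stand for higher toxicity in this test and higher numbers for lower toxicity in this test), compound 1 gives > 50000 nM, which is a limit of the assay and not a measured number. Compound 1 therefore sits at the limit (the limit of > 50000 nM in this assay, at which 1 of the 3 values shown sits), so its true place on the scale is known only as a bound.

Compound 4 `O=c1nc2oc(CCCCCCCCCI)cc2cn1[C@H]1C[C@H](O)[C@@H](CO)O1` is the compound not yet measured. It differs from compound 1 by iodo in place of methyl on a saturated chain carbon, nine bonds along the chain from an aromatic carbon.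

Two measured compounds with a related chain bear on this change. Compound 2 `O=c1[nH]c(=O)n([C@H]2C[C@H](O)[C@@H](CO)O2)cc1C#CCCCCCCCCCCl` gives 200000 nM in this assay, and compound 3 `O=c1[nH]c(=O)n([C@H]2C[C@H](O)[C@@H](CO)O2)cc1C#CCCCCCCCCCBr` gives 50000 nM. Among the measured compounds shown here, the one directly comparable step is a 4.0-fold lower number from compound 2 to compound 3 (0.60 log units; beyond the scatter), where a heavier halogen at the end of the chain lowered the number. Iodine is the heaviest halogen of the three, and the analogy suggests that replacing the terminal methyl with iodo may move compound 4 toward a lower number than compound 1, although compound 1 only provides a bound to start from, so the direction is uncertain.

Compound 4 is therefore expected to give 50000 nM in this assay, within a range from 15000 nM to 150000 nM. The expected step is a number no higher from compound 1 to compound 4 (the limit leaves the size open).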

Compound 4, minimum cytotoxic concentration: 50000 nM
Beside the measured number, compound 4's estimate shows no gap at the digits printed, within the range that was stated.
By their numbers in this assay, from the lowest: compounds 3 and 4 (each within the scatter of the next); then compound 2.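

In this assay, among the compounds shown here, compound 4 gives a measured number on the core of compound 1, whereas the only earlier compound with this core offered no more than a limit. Compound 1 rests on a limit of the assay, so the size of this change stays hidden: the limit of > 50000 nM in this assay, at which 1 of the 4 values shown sits. Iodo in place of methyl on a saturated chain carbon, nine bonds along the chain from an aromatic carbon, gives a number no higher from compound 1 to compound 4 (the limit leaves the size open), so only the direction of the step can be read, and whether the number truly moved cannot.

The compounds shown do not tell where chloro or bromo at this chain end would fall on this core, and the halogen step between compound 2 and compound 3 belongs to a different core with a triple-bonded chain, so it cannot be carried over as an established trend. They also leave open what an amine or a hydroxyl at the chain end would give on this core, and what a longer chain ending in iodo would give.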